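Cinnamate esters of the shared core: cytotoxicity notes

This account rests on a few compounds, and the source may have more. Where it says the series, first, only, none or still open, it means among the compounds named here.

Measured so far:
compound 1, `Cc1nc(C)c(C(=O)Oc2ccc(/C=C/C(=O)O)cc2O)nc1C`: 92.8%
compound 2, `CCOC(=O)/C=C/c1ccccc1OC(=O)c1nc(C)c(C)nc1C`: 9.6%
compound 3, `Cc1nc(C)c(C(=O)Oc2cccc(/C=C/C(=O)O)c2)nc1C`: 61.6%

In a functional assay on EA.hy 926 cells (Homo sapiens) for cytotoxicity, read by MTT assay, with stated times of 24 h and 12 h, tested at 12.5 uM (on this read-out lower numbers stand for a weaker effect and higher numbers for a stronger effect at the one concentration tested), compound 3 stands second of the three numbers. Compound 1 sits higher, a gap beyond the scatter, and compound 2 sits far lower, also beyond the scatter. Compound 2 differs from the others in more than one place, so its low number cannot be tied to a single change.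

Compound 4, `COc1ccc(/C=C/C(=O)O)cc1OC(=O)c1nc(C)c(C)nc1C`, has not yet been measured. It differs from compound 3 in one place: methoxy in place of hydrogen on an aromatic carbon. Among the compounds with values here, no step between measured compounds isolates this change, so the expectation rests on the spread of the measured values alone. Compound 1 carries a small oxygen-bearing group on the same ring and gives 92.8%, which is the only hint that a substituted ring of this kind may read higher than the bare ring of compound 3.

On this basis a moderate rise is expected, with the step of a number 8.4 percentage points higher from compound 3 to compound 4 (within the scatter) estimated as within to just beyond the scatter. Compound 4 is estimated to give 70% in this assay, with a range from 45% to 92%.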

Compound 4, a percentage reported as activity, at one concentration (the size of the read-out at that concentration, not a potency): 41.3%
Beside the measured number, compound 4's estimate is 28.7 percentage points above it; measured number outside the range, below it.
By their numbers in this assay, from the lowest: compound 2; then compound 4; then compound 3; then compound 1.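

In this assay the series now has its first change confined to one place: methoxy in place of hydrogen on an aromatic carbon, ortho to a large group and para to a 2-carboxyethenyl group, comes with a number 20.3 percentage points lower from compound 3 to compound 4 (beyond the scatter) on the read-out at the one concentration tested. Within the data shown here, this position is therefore not silent for the read-out, since a single methoxy of 2 heavy atoms on this ring is enough to move the number downward, a shift the earlier compounds, which differ from one another in more than one place, could not isolate. Nothing in the data shown accounts for this fall.

On these data alone, whether the fall belongs to methoxy itself or would follow any group on this carbon remains open, and an amino group, a chlorine or a longer ethoxy chain in the same place would separate those two readings. Also open, as far as these compounds go, is whether methoxy on another carbon of the same ring would move the number in the same direction, and whether the step holds at concentrations other than the single one used here.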